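A ring replaces the chain in compound 4

This account rests on a few compounds, and the source may have more. Where it says the series, first, only, none or still open, it means among the compounds named here.

Compound 1 `FC(F)(F)c1cccc(NC(=S)Nc2ccc(Cl)cc2)c1` gives 11000 nM
Compound 2 `FC(F)(F)c1cccc(NC(=S)Nc2ccccc2)c1` gives 39000 nM
Compound 3 `C=C(C)CNC(=S)Nc1cccc(C(F)(F)F)c1` gives > 100000 nM (a limit)

Going by the values given here, all three values come from an ADME assay on Vero 76 cells (Chlorocebus sabaeus) for cytotoxicity, read by crystal violet staining, with a stated time of 96 h (a higher number here means that more compound is tolerated, a lower number that less compound is tolerated), and are the only evidence available. Compound 3 stands at > 100000 nM as a limit of the assay and not a number. Compound 4 `Fc1cccc(NC(=S)Nc2cccc(C(F)(F)F)c2)c1` differs from it by one change 3-fluorophenyl in place of 2-methylprop-2-en-1-yl on an amide-type nitrogen in which 3-fluorophenyl takes the place of 2-methylprop-2-en-1-yl on an amide-type nitrogen.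

Two measured steps ran the opposite way: an at least 2.5-fold higher number from compound 2 to compound 3 (0.40 log units; beyond the scatter) when that chain replaced phenyl, and an at least 9.0-fold higher number from compound 1 to compound 3 (0.95 log units; beyond the scatter) when it replaced 4-chlorophenyl. A third step, a 3.5-fold higher number from compound 1 to compound 2 (0.55 log units; beyond the scatter) with hydrogen in place of chloro, shows that a change on the ring can also matter. Bringing a ring back onto this nitrogen should therefore lower the number in this assay by a modest step or more. Compound 4 is expected to fall close to compound 2 at 39000 nM and compound 1 at 11000 nM on this scale. A step of an at least 4.5-fold lower number from compound 3 to compound 4 (0.65 log units; beyond the scatter) is expected, toward less compound tolerated. For compound 4 the estimate is 22000 nM with an expected range of 9000 nM to 55000 nM in this assay.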

Compound 4, half-maximal cytotoxic concentration: 20000 nM
Beside the measured number, compound 4's estimate is 1.1-fold (0.04 log units) above it; the measured number falls inside the stated range.
By their numbers in this assay, from the lowest: compounds 1, 4 and 2 (each within the scatter of the next, the first and the last beyond it). At a limit, above all of these: compound 3.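

In this assay, 3-fluorophenyl in place of the 2-methylprop-2-en-1-yl chain on this amide-type nitrogen gives an at least 5.0-fold lower number from compound 3 to compound 4 (0.69 log units; beyond the scatter), so a third aromatic ring now sits on the same side of the chain as phenyl and 4-chlorophenyl. The size of that step is only a floor, because compound 3 stands at a limit and not at a number: the limit of > 100000 nM in this assay, at which 1 of the 4 values shown sits. The ring's own substitution separates less than the chain swap here: a 2.0-fold lower number from compound 2 to compound 4 (0.29 log units; within the scatter) and a 1.8-fold higher number from compound 1 to compound 4 (0.26 log units; within the scatter) both lie within the scatter, so compound 4 cannot be told apart from either, although compound 1 and compound 2 differ beyond it.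

The compounds shown leave open whether an aromatic ring is what counts on this nitrogen. A cyclohexyl ring or a longer chain there could fall with the aromatic compounds or with compound 3.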